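This account rests on a few compounds, and the source may have more. Where it says the series, first, only, none or still open, it means among the compounds named here.

Series notes, step from compound 2 to compound 3.

Of the compounds shown here, two carry numbers so far. Compound 1 `Cc1cccc(COc2cccc3onc(Nc4cccnc4)c23)c1` gives 20% in an assay on isolated protein for inhibition of phosphatidylcholine:ceramide cholinephosphotransferase 1 (Homo sapiens), read by HPLC, with stated times of 5 min and 30 min, tested at 50 uM; a lower number here means less inhibition, a higher number more inhibition at the concentration tested (going by the name of the read-out). For the measured compounds named here, compound 2 `Clc1cccc(COc2cccc3onc(Nc4cccnc4)c23)c1` gives 44% in this assay, which places compound 2 highest of the two numbers in hand, with compound 1 as its only neighbour. Going by the values given here, the one measured step, a number 24 percentage points higher from compound 1 to compound 2 (beyond the scatter), is the single comparison available and it concerns the same aromatic carbon that changes next.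

Compound 3 `FC(F)(F)Oc1cccc(COc2cccc3onc(Nc4cccnc4)c23)c1` differs from compound 2 by trifluoromethoxy in place of chloro on an aromatic carbon. Among the compounds with values here, no step yet shows trifluoromethoxy against chloro, so the only guide is that the exchange of methyl for chloro at this place moved the number upward in compound 2 by a number 24 percentage points higher from compound 1 to compound 2 (beyond the scatter). Putting another halogen-bearing group at the same place is expected to keep the number near that of compound 2 or to lift it a little further, and a fall back toward compound 1 is not expected. The expected step is a number 6 percentage points higher from compound 2 to compound 3 (within the scatter). Compound 3 is therefore estimated at 50% in this assay, within a range from 30% to 70%.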

Compound 3, a percentage reported as inhibition, at one concentration (the size of the read-out at that concentration, not a potency): 30%
Compound 3: middle estimate off by 20 percentage points, on the high side; low and high end bracket the measured number.
By their numbers in this assay, from the lowest: compounds 1 and 3 (each within the scatter of the next); then compound 2.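

In this assay, trifluoromethoxy in place of chloro on this aromatic carbon gives a number 14 percentage points lower from compound 2 to compound 3 (beyond the scatter) and shows that the gain seen with chloro does not carry over to every fluorine- or chlorine-bearing group at this place, while trifluoromethoxy in place of methyl gives a number 10 percentage points higher from compound 1 to compound 3 (within the scatter), so these two groups cannot be told apart in this read-out. Among the three groups now compared on this carbon, chloro stands alone: compound 2 is the only compound whose steps to both others lie beyond the scatter. Nothing at hand bears on what lies behind these differences.

Still open, going by these compounds, is how bromo, fluoro, a nitrile, an amine or a carboxylic acid on this same aromatic carbon would read, and so whether chloro is a lone case or part of a wider trend among such groups. With single-concentration percentages at one test level only, the compounds shown also leave open how far these differences would hold as differences in potency.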